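From Furan to Methoxyphenyl in a Level Series

The compounds below may be only part of what the source reports. "The series", "measured", "known", "first", "only" and "open" are said of these compounds alone.

In a functional assay, read by spectrophotometry, tested at 100 uM (a lower number here means a stronger inhibitor, a higher number a weaker inhibitor), compound 3 `O=C(/C=C/c1ccco1)c1cccc(NC(=O)c2cc(-c3ccncc3)n[nH]2)c1` gives 72300 nM and sits level with its two relatives: compound 1 `O=C(/C=C/c1cccc2ccccc12)c1cccc(NC(=O)c2cc(-c3ccncc3)n[nH]2)c1` gives 72100 nM and compound 2 `COc1ccc(/C=C/C(=O)c2cccc(NC(=O)c3cc(-c4ccncc4)n[nH]3)c2)cc1` gives 54600 nM in the same test. Compound 4 `COc1ccccc1/C=C/C(=O)c1cccc(NC(=O)c2cc(-c3ccncc3)n[nH]2)c1` carries 2-methoxyphenyl in place of furan-2-yl on a double-bonded chain carbon bound to a double-bonded chain carbon and is otherwise unchanged. Two measured swaps at that place bear on it: a 1.0-fold higher number from compound 1 to compound 3 (0.00 log units; within the scatter) and a 1.3-fold higher number from compound 2 to compound 3 (0.12 log units; within the scatter) are both small, and the second involves 4-methoxyphenyl, the closest match to the incoming group. No change beyond the scatter is therefore expected in this assay here. The estimated step is a 1.2-fold lower number from compound 3 to compound 4 (0.08 log units; within the scatter) and no more. Compound 4 is estimated at 60000 nM with 35000 nM to 100000 nM as the expected range.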

Compound 4, half-maximal inhibitory concentration: 56700 nM
For compound 4 the middle estimate is 1.1-fold (0.02 log units) above the measured one; measured number inside the range.
By their numbers in this assay, from the lowest: compounds 2, 4, 1 and 3 (each within the scatter of the next).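

In this assay, 2-methoxyphenyl in place of 4-methoxyphenyl gives (a 1.0-fold higher number from compound 2 to compound 4 (0.02 log units; within the scatter)), so moving the methoxy group on this ring leaves no readable change. The same group gives (a 1.3-fold lower number from compound 3 to compound 4 (0.11 log units; within the scatter)) against furan-2-yl and (a 1.3-fold lower number from compound 1 to compound 4 (0.10 log units; within the scatter)) against naphthalen-1-yl, so all four groups at this place now stand within the scatter of one another. Nothing measured here offers a reason for this level result.

All four compounds carry an aromatic ring at this place. Going by these compounds, what an amine or a carboxylic acid would do there remains open.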